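Piperidine for Iodoaniline on a Fused Quinone Core

The compounds below may be only part of what the source reports. "The series", "measured", "known", "first", "only" and "open" are said of these compounds alone.

Three compounds have been tested in a functional assay on MCF7 cells (Homo sapiens) for inhibition, read by sulforhodamine B assay; a lower number here means a stronger inhibitor, a higher number a weaker inhibitor:
Compound 1, `O=C1C(Nc2ccc(I)cc2)=CC(=O)c2c1nc1n2[C@H]2OC[C@@H](O)[C@H]2OC1`, gives 3890 nM.
Compound 2, `O=C1C(N2CCCCC2)=CC(=O)c2c1nc1n2[C@H]2OC[C@@H](O)[C@H]2OC1`, gives only a limit of this assay, > 8000 nM.
Compound 3, `O=C1C=C(Nc2ccc(I)cc2)C(=O)c2c1nc1n2[C@H]2OC[C@@H](O)[C@H]2OC1`, gives 2230 nM.

Compounds 1 and 3 have the same atoms joined differently; the difference between their two cores is not broken down here. The values of compound 3 and compound 1 lie within the usual scatter of each other.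

For the measured compounds named here, the one change already measured is piperidin-1-yl in place of (4-iodophenyl)amino on a double-bonded ring carbon, and it gave an at least 2.0-fold higher number from compound 1 to compound 2 (0.31 log units; beyond the scatter). That step can only be bounded because of the limit of > 8000 nM in this assay, at which 1 of the 3 values shown sits.

Compound 4, `O=C1C=C(N2CCCCC2)C(=O)c2c1nc1n2[C@H]2OC[C@@H](O)[C@H]2OC1`, carries the same change on the core of compound 3: piperidin-1-yl in place of (4-iodophenyl)amino on a double-bonded ring carbon. The place is the same in both pairs, so the step is expected to be of similar size, at least a weakening, and compound 4 is estimated to move by a 4.0-fold higher number from compound 3 to compound 4 (0.61 log units; beyond the scatter) from compound 3. Compound 4 is therefore expected to give about 9000 nM in this assay, with a fair chance that only a limit is reported.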

Compound 4, half-maximal inhibitory concentration: > 8000 nM
Compound 4: a limit, no number; the forecaster's own chance of this, stated with the estimate: 60%; the middle value is on the limit's open side.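

In this assay compound 4 gives > 8000 nM, which is a limit of the assay and not a number. Piperidin-1-yl in place of (4-iodophenyl)amino gives an at least 3.5-fold higher number from compound 3 to compound 4 (0.55 log units; beyond the scatter), so on both cores shown the change points the same way, toward a weaker inhibitor: the same change on two cores in this assay, an at least 2.0-fold higher number (0.31 log units; beyond the scatter) from compound 1 to compound 2 and an at least 3.5-fold higher number (0.55 log units; beyond the scatter) from compound 3 to compound 4; the limit leaves it open whether they differ The true size of each step stays unknown, and so does any difference between the two cores, so only the direction can be said to carry over: the limit of > 8000 nM in this assay, at which 2 of the 4 values shown sit.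

The compounds shown leave open which part of (4-iodophenyl)amino matters for the stronger inhibition: the iodine, the aromatic ring or the hydrogen on the nitrogen. A plain phenylamino group without the iodine, or a cyclohexylamino group, which keeps that hydrogen on a non-aromatic ring, would begin to separate these possibilities if placed on each core.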